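The source may report more compounds than this note shows. Statements on the series, on what has been measured and on what is new or still open speak of the compounds shown alone.

Within the data shown here, in an ADME assay on C8166 cells (Homo sapiens) for cytotoxicity, read by MTT assay (a lower number here means that less compound is tolerated, a higher number that more compound is tolerated), two compounds have numbers so far. Compound 1 `Cc1cc(S(N)(=O)=O)ccc1NC(=O)COc1ccc(Cl)cc1C(O)c1cccc(F)c1`, which carries a 3-fluorophenyl group, gives 37600 nM. Compound 2 `Cc1cc(S(N)(=O)=O)ccc1NC(=O)COc1ccc(Cl)cc1C(O)c1cccc(C)c1C`, which carries a 2,3-dimethylphenyl group, gives 218000 nM, the higher of the two numbers. Compound 3 `Cc1ccc(C(O)c2cc(Cl)ccc2OCC(=O)Nc2ccc(S(N)(=O)=O)cc2C)c(C)c1` has the same atoms as compound 2, joined differently: 2,4-dimethylphenyl in place of 2,3-dimethylphenyl on a saturated chain carbon bound to an aromatic carbon and an oxygen on a saturated carbon. Among the measured compounds shown here, only one measured step bears on this change, a 5.8-fold higher number from compound 1 to compound 2 (0.76 log units; beyond the scatter), and it replaced the 3-fluorophenyl group with a 2,3-dimethylphenyl group. The change to compound 3 is narrower, since both of its methyl groups remain and only the ring pattern differs, so a smaller step than that one is expected. A single step gives no firm direction, and nothing beyond the scatter is anticipated. The expected change is a 1.2-fold lower number from compound 2 to compound 3 (0.08 log units; within the scatter). For compound 3 the estimated value is 180000 nM, with an expected range of 75000 nM to 350000 nM.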

Compound 3, half-maximal cytotoxic concentration: 26400 nM
Compound 3: middle estimate off by 6.8-fold (0.83 log units), on the high side; measured number below the stated range.
By their numbers in this assay, from the lowest: compounds 3 and 1 (each within the scatter of the next); then compound 2.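

In this assay, shifting one methyl group on the ring, with the atom count unchanged, gives an 8.3-fold lower number from compound 2 to compound 3 (0.92 log units; beyond the scatter), so at this saturated chain carbon the pattern of the two methyl groups counts and not merely their presence. The 2,4-dimethylphenyl group also reads level with the 3-fluorophenyl group, with a 1.4-fold lower number from compound 1 to compound 3 (0.15 log units; within the scatter), which leaves the high number of compound 2 tied to the 2,3-dimethylphenyl group alone among these three compounds, not to dimethyl substitution as such. Nothing given here explains the gap between the two dimethylphenyl groups.

As far as these compounds go, whether the high number of compound 2 needs both methyl groups, or would survive with a single methyl group or with two chlorine atoms in their place, stays open. Also open, from the compounds shown here alone, is whether the gap between the two dimethylphenyl groups would persist if a ketone carbonyl replaced the hydroxy-bearing carbon.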